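Swapping bromo for 4-methylpiperazin-1-yl on compound 2

The source may hold more compounds than are shown below. What is called first, only, known or untested is meant among the compounds shown, and "the series" means these compounds.

Measured so far in an ADME assay on HepG2 cells (Homo sapiens) for inhibition, read by fluorescence and resazurin assay, with a stated time of 72 h; on this read-out higher numbers stand for weaker inhibition and lower numbers for stronger inhibition 
- compound 1 `Cc1cccc(Nc2nccc(Nc3ccc4cn[nH]c4c3)n2)c1` gives 15000 nM 
- compound 2 `Brc1cccc(Nc2nccc(Nc3ccc4cn[nH]c4c3)n2)c1` gives 17000 nM 

Going by the values given here, with only two numbers to compare, compound 2 (17000 nM) sits level with compound 1 within the scatter. Among the compounds with values here, the single measured step, bromo in place of methyl on an aromatic carbon, is a 1.1-fold higher number from compound 1 to compound 2 (0.05 log units; within the scatter) and so shows no real change.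

Compound 3 `CN1CCN(c2cccc(Nc3nccc(Nc4ccc5cn[nH]c5c4)n3)c2)CC1` carries a bigger alteration, with 4-methylpiperazin-1-yl in place of bromo on an aromatic carbon. Within the data shown here, the only guide is a 1.1-fold higher number from compound 1 to compound 2 (0.05 log units; within the scatter) and no ring entered in that swap, so it bears on this change only weakly. Among the measured compounds shown here, no measured compound yet carries a ring at this place. Nothing measured therefore points to a shift, and a step no larger than the scatter, with no firm direction, is expected in this assay for now. For compound 3 the estimated step is a 1.4-fold lower number from compound 2 to compound 3 (0.15 log units; within the scatter) and the range around it has to stay wide. Compound 3 is expected at about 12000 nM (range 4000 nM to 35000 nM).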

Compound 3, half-maximal inhibitory concentration: 6700 nM
The estimate for compound 3 lay 1.8-fold (0.25 log units) above the measured number; the measured number falls inside the stated range.
By their numbers in this assay, from the lowest: compound 3; then compounds 1 and 2 (each within the scatter of the next).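

This position on the aromatic ring of carbon only showed no real change between methyl and bromo, but it does respond in this assay once a ring enters there. Putting 4-methylpiperazin-1-yl in place of bromo brings a modest move towards stronger inhibition (a 2.5-fold lower number from compound 2 to compound 3 (0.40 log units; beyond the scatter)), and the same group in place of methyl gives a step of similar size (a 2.2-fold lower number from compound 1 to compound 3 (0.35 log units; beyond the scatter)), so both comparisons point the same way. No measured evidence is available to explain why the number falls at this position.

The incoming group differs from bromo and methyl in several ways at once: it has more heavy atoms, a six-membered non-aromatic ring and two nitrogens, and these compounds cannot separate those features. Going by these compounds, it remains open whether a simple open-chain amine such as dimethylamino, or a morpholine ring with oxygen in place of the methyl-bearing nitrogen, would move the number in the same direction at this position.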